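Extending an Ether Chain on Two Methoxyphenyl Indole Cores

The source may report more compounds than this note shows. Statements on the series, on what has been measured and on what is new or still open speak of the compounds shown alone.

Compound 1 `CCOc1ccc2[nH]c(-c3ccc(OC)cc3)c(C3=C(Br)C(=O)NC3=O)c2c1` and compound 2 `CCCCOc1ccc2[nH]c(-c3ccc(OC)cc3)c(C3=C(Br)C(=O)NC3=O)c2c1` share a core and differ only by ethyl in place of hydrogen on a saturated chain carbon, two bonds along the chain from an oxygen on an aromatic ring. In a physicochemical assay for lipophilicity (a higher number here means a more lipophilic compound, a lower number a more polar compound), compound 1 gives 2.77, and compound 2 gives 3.43. That step measures a number 0.66 log units higher from compound 1 to compound 2 (beyond the scatter). Compound 3 `CCOc1ccc2[nH]c(-c3cccc(OC)c3)c(C3=C(Br)C(=O)NC3=O)c2c1` carries a different core, the difference being (3-methoxyphenyl in place of 4-methoxyphenyl on an aromatic carbon). In this assay compound 3 gives 2.97. The corresponding step reads a number 0.20 log units higher from compound 1 to compound 3 (within the scatter). Compound 4 `CCCCOc1ccc2[nH]c(-c3cccc(OC)c3)c(C3=C(Br)C(=O)NC3=O)c2c1` has not yet been measured in this assay. It differs from compound 3 by ethyl in place of hydrogen on a saturated chain carbon, two bonds along the chain from an oxygen on an aromatic ring, which is the same change as that between compound 1 and compound 2, made at the same place; among the compounds shown this change occurs twice in all. Within the data shown here, because the one measured instance gave a number 0.66 log units higher from compound 1 to compound 2 (beyond the scatter), a step of similar size is expected for compound 4, namely a number 0.66 log units higher from compound 3 to compound 4 (beyond the scatter), and this expectation rests on that single pair alone. Compound 4 is therefore estimated at 3.63 in this assay. The estimate for compound 4 is expected to fall between 3.3 and 3.95.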

Compound 4, partition coefficient: 3.46
Compound 4: the middle estimate sits 0.17 log units above what was measured, within the range that was stated.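

On the core of compound 3, ethyl in place of hydrogen on the saturated chain carbon gave a number 0.49 log units higher from compound 3 to compound 4 (beyond the scatter) in this assay, and on the core of compound 1 the same change gave a number 0.66 log units higher from compound 1 to compound 2 (beyond the scatter), so both steps run the same way and both lie beyond the scatter. With the butoxy chain in place, the choice of 3-methoxyphenyl or 4-methoxyphenyl leaves a number 0.03 log units higher from compound 2 to compound 4 (within the scatter) and the two compounds cannot be told apart in this measurement. This shows that the change carried over between these two cores, but two pairs do not show that it would carry to any other core, and nothing available accounts for the result.

The compounds shown hold only ethoxy and butoxy chains on two methoxyphenyl cores. From the compounds shown here alone, whether the step would persist for a longer chain such as hexyloxy, for a chain ending in an amine or a carboxylic acid, or on a core with an unsubstituted phenyl remains open.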